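Adding isopropyl to the amide methyl of compound 1

This account rests on a few compounds, and the source may have more. Where it says the series, first, only, none or still open, it means among the compounds named here.

In a functional assay on Huh-7 cells (Homo sapiens) for antiproliferative activity, read by CCK-8 assay, with a stated time of 72 h (a higher number here means a weaker inhibitor of growth, a lower number a stronger inhibitor of growth), the compounds measured so far give these values
Compound 1 `CCC1C(=O)N(C)c2cnc(-n3ccc4cc(C(=O)NC)ccc43)nc2N1c1ccn(C)n1` gives 13200 nM
Compound 2 `CCCNC(=O)c1ccc2c(ccn2-c2ncc3c(n2)N(C2CCCC2)[C@H](CC)C(=O)N3C)c1` gives 689 nM

Of these two numbers, compound 1 holds the higher one, so it is the weaker inhibitor of growth, and the gap to compound 2 lies beyond the usual scatter of repeated measurements.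

Compound 3 `CCC1C(=O)N(C)c2cnc(-n3ccc4cc(C(=O)NCC(C)C)ccc43)nc2N1c1ccn(C)n1` keeps the core of compound 1 and changes in one place. The change is isopropyl in place of hydrogen on a saturated chain carbon bound to an amide-type nitrogen and it puts isopropyl in place of hydrogen on a saturated chain carbon bound to an amide-type nitrogen, turning methylcarbamoyl into isobutylcarbamoyl.

Among the measured compounds shown here, no two measured compounds differ in just one place, so no measured step can serve as a guide. For the measured compounds named here, the only hint is that compound 2 at 689 nM shows that this family can reach a much lower number than compound 1 at 13200 nM in this assay and so a modest move downward is expected, though one within the scatter would be no surprise. The expected change is a 2.6-fold lower number from compound 1 to compound 3 (0.42 log units; beyond the scatter) and this is only an estimate. For compound 3 the expected value is 5000 nM with an estimated range from 1500 nM to 16000 nM in this assay as the measure.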

Compound 3, concentration for 50% growth inhibition: 5070 nM
Beside the measured number, compound 3's estimate is 1.0-fold (0.01 log units) below it; the range from low to high includes it.
By their numbers in this assay, from the lowest: compound 2; then compound 3; then compound 1.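

In this assay, the side chain on the amide grows from methylcarbamoyl to isobutylcarbamoyl, and this gives a 2.6-fold lower number from compound 1 to compound 3 (0.42 log units; beyond the scatter). Among the compounds shown here, the step is modest, but it is the first direct reading at this position, and it shows that isopropyl, with its 3 heavy atoms and no hydrogen-bond donors or acceptors, can replace hydrogen on the saturated chain carbon bound to an amide-type nitrogen without raising the number. Nothing available explains why the number falls, so this remains an observation about one pair of compounds.

A single step cannot show whether the number keeps falling as the chain grows or whether the branched isobutyl shape matters, and a straight butyl chain, a longer chain, or a chain ending in an amine or a carboxylic acid would each help separate these possibilities. On these data alone, it also remains open whether the change would act the same way with other groups elsewhere on the molecule, since compound 2 differs from compound 1 and compound 3 in more than one place and its steps to them cannot be read.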